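The source may report more compounds than this note shows. Statements on the series, on what has been measured and on what is new or still open speak of the compounds shown alone.

Measured in a functional assay on the whole organism with Rattus norvegicus as the target; a lower number here means that less compound is needed, a higher number that more compound is needed for the effect:
- Compound 1 `CCCCn1c(=N)sc2cc(OC(F)(F)F)ccc21` gives 10 mg/kg
- Compound 2 `N=c1sc2cc(OC(F)(F)F)ccc2n1CC(=O)O` gives > 10 mg/kg, which is a limit
- Compound 3 `CN(C)S(=O)(=O)CCn1c(=N)sc2cc(OC(F)(F)F)ccc21` gives > 10 mg/kg, which is a limit

Compound 3 therefore has no exact number and stands at the limit of > 10 mg/kg in this assay, at which 2 of the 3 values shown sit. Compound 4 `CSCn1c(=N)sc2cc(OC(F)(F)F)ccc21` carries methylsulfanyl in place of (dimethylsulfamoyl)methyl on a saturated chain carbon bound to an aromatic nitrogen. Within the data shown here, two measured steps bear on this: a number no lower from compound 1 to compound 3 (the limit leaves the size open) and a number no lower from compound 1 to compound 2 (the limit leaves the size open). Neither has a readable size. Neither carboxy nor dimethylsulfamoyl remains in compound 4, so the expectation leans on compound 1 at 10 mg/kg. In this assay the expected change is an at least 1.6-fold lower number from compound 3 to compound 4 (0.22 log units; that floor lies within the scatter), towards a lower dose, though with little certainty. For compound 4 the estimate is 6 mg/kg, with an expected range of 2 mg/kg to 15 mg/kg.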

Compound 4, dose for half-maximal effect: 3 mg/kg
For compound 4 the middle estimate is 2.0-fold (0.30 log units) above the measured one, within the range that was stated.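

In this assay, the place on a saturated chain carbon bound to an aromatic nitrogen now gives its first exact step, with methylsulfanyl in place of propyl: a 3.3-fold lower number from compound 1 to compound 4 (0.52 log units; beyond the scatter). The same group in place of the larger (dimethylsulfamoyl)methyl gives an at least 3.3-fold lower number from compound 3 to compound 4 (0.52 log units; beyond the scatter), and in place of carboxy it gives an at least 3.3-fold lower number from compound 2 to compound 4 (0.52 log units; beyond the scatter), so this place can move the dose lower as well as higher. The earlier steps among compounds 1, 2 and 3 cannot be read, and compound 2 and compound 3 remain limits: the limit of > 10 mg/kg in this assay, at which 2 of the 4 values shown sit.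

As far as these compounds go, whether the sulfur itself matters stays open, as a methoxy group would test. So does the effect of a longer chain such as ethylsulfanyl or of an amine at this place.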